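The source may hold more compounds than are shown below. What is called first, only, known or untested is meant among the compounds shown, and "the series" means these compounds.

Values in a functional assay on HeLa cells (Homo sapiens) for inhibition, read by CCK-8 assay, with a stated time of 72 h, tested at 2 uM (a lower number here means less inhibition of growth, a higher number more inhibition of growth at the concentration tested), stand as follows

compound 1 `Cc1cc(C)cc(SCc2ccc(/C=C/C(=O)Nc3ccccc3N)cc2)c1` gives 11.7%
compound 2 `Nc1ccccc1NC(=O)/C=C/c1ccc(CSc2cccc(F)c2)cc1` gives 2.25%
compound 3 `CCc1ccc(SCc2ccc(C(=O)Nc3ccccc3N)cc2)cc1` gives 30.8%

Of these three, compound 3 stands highest at 30.8% and lies beyond the scatter from both others, with compound 1 the nearer and compound 2 the further. Compound 4 `Nc1ccccc1NC(=O)c1ccc(CSc2ccc(Br)cc2)cc1` differs from it in one place. The change is bromo in place of ethyl on an aromatic carbon and reads as 4-ethylphenyl to 4-bromophenyl.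

Going by the values given here, only one measured step bears on this, and only loosely. It is a number 9.5 percentage points lower from compound 1 to compound 2 (within the scatter) and it also swaps a group on the aromatic ring attached to sulfur. That step stayed within the scatter, but it starts from a much lower value and the core of compound 1 is not that of compound 3. Among the compounds with values here, no measured step shows a bromo group. A small step in this assay is therefore expected, perhaps slightly downward, and none beyond the scatter is predicted. The estimated step is a number 4.8 percentage points lower from compound 3 to compound 4 (within the scatter) and it is expected to stay within the scatter. For compound 4 the expected value is 26% with an estimated range of 10% to 45% in this read-out.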

Compound 4, percent growth inhibition at one concentration: 18.8%
For compound 4 the middle estimate is 7.2 percentage points above the measured one, and the stated range covers the measured number.
By their numbers in this assay, from the lowest: compounds 2, 1 and 4 (each within the scatter of the next, the first and the last beyond it); then compound 3.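

With the shared core held constant, this assay records a number 12 percentage points lower from compound 3 to compound 4 (beyond the scatter) when 4-ethylphenyl gives way to 4-bromophenyl, on an aromatic carbon para to a large group. The only earlier step that changed this aromatic ring, a number 9.5 percentage points lower from compound 1 to compound 2 (within the scatter), stayed within the scatter and belonged to a different core, so this is the first change on that ring shown to move the read-out beyond the scatter. No measurement given here accounts for the step.

From the compounds shown here alone, the two compounds alone cannot separate the loss of ethyl from the arrival of bromo, and what a chloro group, a methoxy group, an amine or a propyl chain would give at this place remains open. Going by these compounds, whether the same change would move the read-out on the core of compound 1 also remains open.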